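The source may hold more compounds than are shown below. What is called first, only, known or untested is meant among the compounds shown, and "the series" means these compounds.

Measured so far:
compound 1 `Clc1ccc(-c2nnc(-c3nsc4ccccc34)o2)cc1` 33%
compound 2 `CNc1nnc(-c2nsc3ccccc23)o1` 60%
compound 3 `CCNc1nnc(-c2nsc3ccccc23)o1` 42%

In a functional assay on the whole organism for inhibition, with Rattus norvegicus as the target, with a stated time of 3.5 h, at a dose of 100 mg/kg by the intraperitoneal route (on this read-out lower numbers stand for less inhibition and higher numbers for more inhibition at the one dose given (going by the name of the read-out)), compound 3 stands second highest of the three numbers. Its nearest neighbour is compound 1, whose value lies within the scatter of it, as a number 9 percentage points higher from compound 1 to compound 3 (within the scatter) shows; the gap to compound 2 is larger, a number 18 percentage points lower from compound 2 to compound 3 (beyond the scatter) being beyond the scatter. Compound 4 `Clc1ccc(Nc2nnc(-c3nsc4ccccc34)o2)cc1` is not yet measured. It differs from compound 3 by 4-chlorophenyl in place of ethyl on a nitrogen on an aromatic ring.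

Going by the values given here, no measured step exchanges an alkyl for an aryl on that nitrogen, so the bearing is indirect. The step of a number 18 percentage points lower from compound 2 to compound 3 (beyond the scatter) shows that a larger group on the nitrogen went with a modest drop, and a number 27 percentage points higher from compound 1 to compound 2 (beyond the scatter) shows that a 4-chlorophenyl attached directly to the core gave the lowest number of the three. Both hints point the same way, but neither is the change at hand, and compound 2 alone carries the highest number, so the evidence is thin.

Compound 4 is therefore expected to come out somewhat lower than compound 3, with a step of about a number 12 percentage points lower from compound 3 to compound 4 (beyond the scatter) that need not exceed the scatter. The estimate for compound 4 is 30%, within a range of 10% to 52%.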

Compound 4, a percentage reported as inhibition, in the whole organism at one dose (the size of the read-out at that dose, not a potency): 40%
Compound 4: middle estimate off by 10 percentage points, on the low side, within the range that was stated.
By their numbers in this assay, from the lowest: compounds 1, 4 and 3 (each within the scatter of the next); then compound 2.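

In this assay, going by these compounds alone, the first exchange of an alkyl for an aryl group on this nitrogen gives a number 2 percentage points lower from compound 3 to compound 4 (within the scatter) and so leaves the read-out where it was, although 4-chlorophenyl brings a six-membered aromatic ring and more heavy atoms than ethyl. Set against the smallest group on this nitrogen, the same 4-chlorophenyl gives a number 20 percentage points lower from compound 2 to compound 4 (beyond the scatter) and thus falls about as far as the step of a number 18 percentage points lower from compound 2 to compound 3 (beyond the scatter) does, so among these three compounds methyl stands apart, while ethyl and 4-chlorophenyl cannot be told apart. Nothing available explains why methyl differs from the other two groups at this position.

Going by these compounds, it stays open whether the free amine, a propyl chain or a phenyl group without the chlorine on this nitrogen would match compound 2 or sit with compound 3 and compound 4. Each number in this assay also comes from a single dose, so the compounds shown leave open whether the same grouping would hold at other doses or at other times.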